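The source may report more compounds than this note shows. Statements on the series, on what has been measured and on what is new or still open speak of the compounds shown alone.

Compound 3 `COc1ccc(-n2cc(C(=O)Nc3ccc(Oc4ccnc5c4ccn5C)c(F)c3)c(=O)c3ccccc32)cc1` gives 3210 nM in a functional assay on A549 cells (Homo sapiens) for inhibition, read by MTT assay, with a stated time of 72 h (on this read-out higher numbers stand for weaker inhibition and lower numbers for stronger inhibition), the highest number of the three measured. Compound 1 `Cn1ccc2c(Oc3ccc(NC(=O)c4cn(-c5ccc(F)cc5)c5ccccc5c4=O)cc3F)ccnc21` gives 1460 nM and compound 2 `Cn1ccc2c(Oc3ccc(NC(=O)c4cn(-c5ccc(F)c(Cl)c5)c5ccccc5c4=O)cc3F)ccnc21` gives 1210 nM; the steps of a 2.2-fold higher number from compound 1 to compound 3 (0.34 log units; beyond the scatter) and a 2.7-fold higher number from compound 2 to compound 3 (0.42 log units; beyond the scatter) place compound 3 at the weak end, while a 1.2-fold lower number from compound 1 to compound 2 (0.08 log units; within the scatter) stays within the scatter. Compound 4 `COc1ccc(-n2cc(C(=O)Nc3ccc(Oc4ccnc5[nH]ccc45)c(F)c3)c(=O)c3ccccc32)cc1` differs from compound 3 by hydrogen in place of methyl on an aromatic nitrogen. Going by the values given here, none of the measured steps touches that nitrogen: all three alter the aryl group or its substituents and leave the methylated ring unchanged. No measured guidance on direction exists, so the expected step of a 1.1-fold lower number from compound 3 to compound 4 (0.03 log units; within the scatter) is taken as none beyond the scatter, with wide uncertainty. Compound 4 is estimated at 3000 nM, within a range of 1100 nM to 8000 nM.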

Compound 4, half-maximal inhibitory concentration: 4150 nM
Beside the measured number, compound 4's estimate is 1.4-fold (0.14 log units) below it, and the stated range covers the measured number.
By their numbers in this assay, from the lowest: compounds 2 and 1 (each within the scatter of the next); then compounds 3 and 4 (each within the scatter of the next).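

First read on the aromatic nitrogen of the five-membered ring: in this assay the change gives a 1.3-fold higher number from compound 3 to compound 4 (0.11 log units; within the scatter), so hydrogen and methyl at this position are not told apart on this read-out. This holds only with the 4-methoxyphenyl group on the other aromatic nitrogen. No measured evidence bears on this result. Open, on these data alone, is whether hydrogen in place of methyl gives the same outcome with the 3-chloro-4-fluorophenyl group of compound 2. Also open, as far as these compounds go, is what an ethyl group or a longer chain ending in an amine would do on this nitrogen.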